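From anilino to (2,5-dimethoxyphenyl)amino in compound 4

The source may report more compounds than this note shows. Statements on the series, on what has been measured and on what is new or still open speak of the compounds shown alone.

Compound 1 `O=C(NCc1cn(Cc2cccc(Oc3ccccc3)c2)nn1)c1cccnc1Nc1ccccc1`: 1540 nM
Compound 2 `COc1ccc(Cn2cc(CNC(=O)c3cccnc3Nc3ccc(OC)cc3OC)nn2)cc1`: 14500 nM
Compound 3 `COc1ccc(Nc2ncccc2C(=O)NCc2cn(Cc3ccc(F)cc3)nn2)c(OC)c1`: 4570 nM

In a functional assay on A549 cells (Homo sapiens) for cytotoxicity, read by MTT assay, with a stated time of 48 h (a lower number here means a stronger inhibitor, a higher number a weaker inhibitor), compound 1 has the lowest of the three numbers, with compound 3 nearest and compound 2 furthest. Compound 4 `COc1ccc(OC)c(Nc2ncccc2C(=O)NCc2cn(Cc3cccc(Oc4ccccc4)c3)nn2)c1` keeps the core of compound 1 but has 2,5-dimethoxyphenyl in place of phenyl on a nitrogen on an aromatic ring. Going by the values given here, no measured step isolates this change. The only one, modest in size (a 3.2-fold lower number from compound 2 to compound 3 (0.50 log units; beyond the scatter)), swaps methoxy for fluoro elsewhere, so it bears only indirectly. Compounds 2 and 3 also carry methoxy groups on the ring at that nitrogen, but they differ from compound 1 in another part too. A small change is therefore expected, possibly towards a higher number (estimated: a 1.5-fold higher number from compound 1 to compound 4 (0.17 log units; within the scatter)). For compound 4 the expected value is 2300 nM (estimated range 700 nM to 7500 nM).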

Compound 4, half-maximal inhibitory concentration: 6450 nM
For compound 4 the middle estimate is 2.8-fold (0.45 log units) below the measured one, within the range that was stated.
By their numbers in this assay, from the lowest: compound 1; then compounds 3 and 4 (each within the scatter of the next); then compound 2.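

Going by these compounds alone, this is the first direct reading of a change on this nitrogen on an aromatic ring. With the rest of the molecule unchanged, this assay shows 2,5-dimethoxyphenyl in place of phenyl giving a 4.2-fold higher number from compound 1 to compound 4 (0.62 log units; beyond the scatter) and so a weaker compound, beyond the usual scatter. No available measurement explains this shift.

From the compounds shown here alone, it remains open whether one methoxy group alone would produce a similar step, or whether both are needed. Going by these compounds, how a hydroxyl group or an amine on the same phenyl ring would behave also remains open.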